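A few compounds are considered here, and "the series" means these few. Any claim that something is new, unique, unknown or untested is made for them only; others in the source may bear on it.

Working notes on the ring-nitrogen substituent. Compound 1 `CC(C)c1onc(-c2c(Cl)cccc2Cl)c1COc1ccc(-c2nc3ccc(C(=O)O)cc3n2CC(C)(C)C)cc1` gives 24.8 nM in an assay on isolated protein for agonist activity at Bile acid receptor (Homo sapiens), read by TR-FRET; a higher number here means that more compound is needed for the effect, a lower number that less compound is needed. Compound 2 `CCn1c(-c2ccc(OCc3c(-c4c(Cl)cccc4Cl)noc3C(C)C)cc2)nc2ccc(C(=O)O)cc21` gives 19.3 nM in this assay. Compound 3 `CC(C)c1onc(-c2c(Cl)cccc2Cl)c1COc1ccc(-c2nc3ccc(C(=O)O)cc3n2C2CC2)cc1` gives 117 nM in this assay, the highest of the three numbers. The two measured steps onto the cyclopropyl of compound 3 are a 4.7-fold higher number from compound 1 to compound 3 (0.67 log units; beyond the scatter) and a 6.1-fold higher number from compound 2 to compound 3 (0.78 log units; beyond the scatter), both modest and both beyond the scatter. Compound 4 `CCCC(CCC)n1c(-c2ccc(OCc3c(-c4c(Cl)cccc4Cl)noc3C(C)C)cc2)nc2ccc(C(=O)O)cc21` differs from compound 3 by 1-propylbutyl in place of cyclopropyl on an aromatic nitrogen. Since both open-chain alkyls on this nitrogen gave lower numbers than cyclopropyl, the change to another open-chain alkyl is expected to lower the number, though 1-propylbutyl is unlike either tested chain and the size of the effect is uncertain. The step expected for compound 4 is a 3.9-fold lower number from compound 3 to compound 4 (0.59 log units; beyond the scatter). Compound 4 is estimated at 30 nM, within 10 nM to 100 nM.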

Compound 4, half-maximal effective concentration: 30.3 nM
The estimate for compound 4 lay 1.0-fold (0.00 log units) below the measured number; the range from low to high includes it.
By their numbers in this assay, from the lowest: compounds 2, 1 and 4 (each within the scatter of the next); then compound 3.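

In this assay the step of a 1.6-fold higher number from compound 2 to compound 4 (0.20 log units; within the scatter) and the step of a 1.2-fold higher number from compound 1 to compound 4 (0.09 log units; within the scatter) both lie within the scatter, so 1-propylbutyl, with 7 heavy atoms, cannot be told apart from ethyl or neopentyl on this aromatic nitrogen. The open-chain groups from ethyl to 1-propylbutyl thus show no measurable change, and the step of a 3.9-fold lower number from compound 3 to compound 4 (0.59 log units; beyond the scatter) leaves cyclopropyl, the only ring among these groups, as the one set apart. Nothing shown bears on why cyclopropyl differs. Open, as far as these compounds go, is whether cyclobutyl or cyclohexyl on this nitrogen would follow cyclopropyl or the open-chain groups. Also open, from the compounds shown here alone, is whether a longer chain ending in an amine or a hydroxyl would be accepted here.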